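A few compounds are considered here, and "the series" means these few. Any claim that something is new, unique, unknown or untested is made for them only; others in the source may bear on it.

Measured so far in a functional assay on HCT-116 cells (Homo sapiens) for antiproliferative activity, read by MTT assay, with a stated time of 72 h; on this read-out lower numbers stand for stronger inhibition and higher numbers for weaker inhibition:
- compound 1 `COc1c(NS(=O)(=O)c2ccc(F)cc2)cc(-c2ccc3nc(NC(C)=O)sc3c2)cc1C(N)=O`: 1950 nM
- compound 2 `NC(=O)c1cc(NS(=O)(=O)c2ccc(F)cc2)cc(-c2ccc3nc(NC(=O)C4CC4)sc3c2)c1`: > 50000 nM
- compound 3 `COc1c(NS(=O)(=O)c2ccc(F)cc2)cc(-c2ccc3nc(NC4CC4)sc3c2)cc1C(N)=O`: > 50000 nM

Compound 1 gives a real number in this assay. For compound 2 the assay returned only a limit, not a number. For compound 3 the result is likewise only a limit, so compound 3 stands at the limit of > 50000 nM in this assay, at which 2 of the 3 values shown sit; nothing finer is known about it.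

Compound 4 `COc1c(NS(=O)(=O)c2ccc(F)cc2)cc(-c2ccc3nc(NC(=O)C4CC4)sc3c2)cc1C(N)=O` differs from compound 3 in one place: cyclopropylcarbonyl in place of cyclopropyl on a nitrogen on an aromatic ring. Among the compounds with values here, this is the reverse of the one measured step that touches this position, an at least 25-fold higher number from compound 1 to compound 3 (1.40 log units; beyond the scatter), which was large and ran from an amide on that nitrogen to a bare cyclopropyl. Restoring an amide should therefore move the number back down, beyond the scatter. Compound 2, however, also returned only a limit, which tempers how far down the number is expected to go.

Compound 4 is expected at 5000 nM, in the range 1500 nM to 50000 nM. That expectation means a step of an at least 10-fold lower number from compound 3 to compound 4 (1.00 log units; beyond the scatter).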

Compound 4, half-maximal inhibitory concentration: 2010 nM
Estimate against measurement, compound 4: 2.5-fold (0.40 log units) above, and the stated range covers the measured number.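

In this assay, the carbonyl on this nitrogen counts for far more than what it carries: restoring it gives an at least 24-fold lower number from compound 3 to compound 4 (1.39 log units; beyond the scatter), while cyclopropyl in place of methyl on that carbonyl gives a 1.0-fold higher number from compound 1 to compound 4 (0.01 log units; within the scatter), a difference within the scatter. The amide is not enough by itself, since methoxy in place of hydrogen on an aromatic carbon gives an at least 24-fold lower number from compound 2 to compound 4 (1.39 log units; beyond the scatter), so here the activity depends on both features. Both of these large steps start from a compound that returned only a limit, so each gives a minimum size and not an exact one: the limit of > 50000 nM in this assay, at which 2 of the 4 values shown sit.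

Only methyl and cyclopropyl on the carbonyl appear here, so two examples say little about how much room this position has. Going by these compounds, whether a longer chain, a phenyl ring or an amine on that carbonyl would keep, improve or lose the activity remains open.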